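Swapping Chloro for Bromo on Compound 1

The source may hold more compounds than are shown below. What is called first, only, known or untested is meant among the compounds shown, and "the series" means these compounds.

Measured so far:
compound 1 `O=C(Nc1ccc(C(F)(F)F)cc1)c1cc(Cl)ccc1O` gives 5800 nM
compound 2 `C/C(=N\OCC(=O)N[C@H](C(=O)N[C@@H](CCCCN)C(=O)N1CCC[C@H]1C(=O)N[C@@H](CCCCN)C(=O)NCC(=O)O)[C@@H](C)O)c1ccc(NC(=O)c2cc(Br)ccc2O)cc1` gives 191000 nM

Both numbers come from a functional assay on HepG2 cells (Homo sapiens) for cytotoxicity, read by MTT assay, with a stated time of 24 h (a lower number here means a stronger inhibitor, a higher number a weaker inhibitor), and compound 1 stands lowest of the two, which makes it the stronger inhibitor of this pair. The gap between compound 1 and compound 2 lies well beyond the usual scatter of repeated measurements.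

Compound 3 `O=C(Nc1ccc(C(F)(F)F)cc1)c1cc(Br)ccc1O` is still unmeasured. Its difference from compound 1 is bromo in place of chloro on an aromatic carbon. The change is bromo in place of chloro on an aromatic carbon, para to a hydroxy group. Nothing else in the structure changes.

Among the measured compounds shown here, no two measured compounds differ in just one place, so the data hold no direct example of such a swap. Starting from compound 1 at 5800 nM the expectation in this assay is no step beyond the scatter, in either direction. The estimated change is a step of a 1.2-fold lower number from compound 1 to compound 3 (0.06 log units; within the scatter) and it is expected to stay within that scatter. For compound 3 the estimated value is 5000 nM with an expected range from 2400 nM to 11000 nM across repeat measurements.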

Compound 3, half-maximal inhibitory concentration: 5500 nM
For compound 3 the middle estimate is 1.1-fold (0.04 log units) below the measured one; measured number inside the range.
By their numbers in this assay, from the lowest: compounds 3 and 1 (each within the scatter of the next); then compound 2.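

In this assay, among the compounds shown here, bromo in place of chloro on an aromatic carbon, para to a hydroxy group, gives a 1.1-fold lower number from compound 1 to compound 3 (0.02 log units; within the scatter), and this is the first comparison in the set in which only one place changes. For the compounds shown here, on the core of compound 1, then, this position accepts either chloro or bromo with no difference that can be separated from the ordinary variation between repeat measurements, something that the earlier compounds, which differ in many places at once, could not show. Nothing available here points to what lies behind this match between the two groups.

Going by these compounds, a single exchange of chloro for bromo says little about the position as a whole, so it remains open whether an amine, a carboxylic acid or a longer alkyl chain on the same aromatic carbon would leave the number just as unmoved or shift it well beyond the scatter. On these data alone, it is also open whether the swap would stay this small on a core that carries a nitrile or a methoxy group in place of the trifluoromethyl group.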